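Benzamide versus cinnamide anilides with arylthiomethyl groups

This account rests on a few compounds, and the source may have more. Where it says the series, first, only, none or still open, it means among the compounds named here.

Measured so far, growth inhibition at one concentration:
compound 1 `Nc1ccccc1NC(=O)/C=C/c1ccc(CSc2cccc(F)c2)cc1`: 8.25%
compound 2 `Nc1ccccc1NC(=O)c1ccc(CSc2cccc(F)c2)cc1`: 83%
compound 3 `Cc1ccc(SCc2ccc(/C=C/C(=O)Nc3ccccc3N)cc2)cc1`: 22.2%

In a functional assay on SMMC-7721 cells (Homo sapiens) for inhibition, read by CCK-8 assay, with a stated time of 72 h, tested at 8 uM (a higher number here means more inhibition of growth at the concentration tested, a lower number less inhibition of growth), compound 2 gives the highest number of the three; compound 1 gives 8.25% and compound 3 gives 22.2%, both beyond the scatter below compound 2. The difference between the core of compound 1 and the core of compound 2 is not broken down here.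

One change is seen twice. From compound 1 to compound 3 it reads 4-methylphenyl in place of 3-fluorophenyl on a sulfur and gives a number 14 percentage points higher from compound 1 to compound 3 (beyond the scatter). From compound 2 to compound 4 `Cc1ccc(SCc2ccc(C(=O)Nc3ccccc3N)cc2)cc1` the same change is made, (4-methylphenyl in place of 3-fluorophenyl on a sulfur), on the core of compound 2.

Compound 4 is not yet measured in this assay. Because compound 2 already stands at 83%, little room remains upward, and the step from compound 1 to compound 3 is modest; a step of about a number 5 percentage points higher from compound 2 to compound 4 (within the scatter) is expected, smaller than the earlier one. Compound 4 is estimated at 88%, with a range from 72% to 98%.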

Compound 4, percent growth inhibition at one concentration: 82.7%
The estimate for compound 4 lay 5.3 percentage points above the measured number; measured number inside the range.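

In this assay, 4-methylphenyl in place of 3-fluorophenyl on a sulfur gives a number 0.3 percentage points lower from compound 2 to compound 4 (within the scatter) on the core of compound 2. The change therefore does not carry over at the same size from one core to the other: the same change on two cores in this assay, a number 14 percentage points higher (beyond the scatter) from compound 1 to compound 3 and a number 0.3 percentage points lower (within the scatter) from compound 2 to compound 4, 14.3 percentage points apart, beyond the scatter of two such steps With one pair on each core and a single tested concentration, this does not show whether the gap would hold for other groups on the sulfur, nor whether the step on the core of compound 2 is limited by the top of the read-out.

The compounds shown leave open how the two cores respond to a different kind of group on the sulfur, such as an aminophenyl, a carboxyphenyl or a longer alkyl chain. They also leave open whether compound 2 and compound 4 would remain level at lower concentrations, where a full concentration-response comparison could separate them.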